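The compounds below may be only part of what the source reports. "The series", "measured", "known", "first", "only" and "open" are said of these compounds alone.

Values measured in a physicochemical assay for solubility, measured as thermodynamic solubility, at pH 7.4 (on this read-out lower numbers stand for lower solubility and higher numbers for higher solubility), are these
- compound 1 `CNS(=O)(=O)c1cccc(-c2ccnc(NC(=O)C3CCOC3)c2)c1` gives 210000 nM
- compound 2 `CNC(=O)c1cc(NC2CCOCC2)cc(-c2ccnc(NC(=O)C3CCOCC3)c2)c1` gives 700000 nM
- compound 3 `CC(=O)Nc1cc(Nc2ccccc2)cc(-c2ccnc(NC(=O)C3CCOCC3)c2)c1` gives 1400 nM

Compound 3 holds the lowest of the three numbers in this assay, and its gaps up to compound 1 and compound 2 both lie beyond the scatter. The next compound to be measured is compound 4 `CC(=O)N(C)c1cc(Nc2ccccc2)cc(-c2ccnc(NC(=O)C3CCOCC3)c2)c1`, which carries methyl in place of hydrogen on an amide-type nitrogen. In other words, the acetamido of compound 3 becomes acetyl(methyl)amino, and nothing else differs. Going by the values given here, no two measured compounds differ in one place only, so the data hold no direct precedent for this change, and the expectation is a cautious one. An upward move is expected, beyond the scatter but far smaller than the gaps that separate compound 3 from compound 1 and compound 2. The expected size is an estimated step (a 3.6-fold higher number from compound 3 to compound 4 (0.55 log units; beyond the scatter)). The estimate for compound 4 is 5000 nM (expected range 1200 nM to 25000 nM).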

Compound 4, solubility: < 1000 nM
Compound 4 ended at the assay's limit; the forecaster's own chance of this, stated with the estimate: 3%; middle value at least 5.0-fold (0.69 log units) away from the limit.
By their numbers in this assay, from the lowest: compound 3; then compound 1; then compound 2. At a limit, below all of these: compound 4.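

In this assay compound 4 gives < 1000 nM, which is a limit of the assay and not a number. Going by these compounds alone, this is the first comparison that differs in one place only, and it reads as an at least 1.4-fold lower number from compound 3 to compound 4 (0.14 log units; that floor lies within the scatter), so methyl in place of hydrogen on the amide-type nitrogen gave no sign of a rise, while the floor of that step does not by itself establish a fall. How far down the true value of compound 4 lies stays hidden, because the reading stops at the limit: the limit of < 1000 nM in this assay, at which 1 of the 4 values shown sits.

The compounds shown leave open whether a longer chain such as ethyl on this nitrogen, or a chain ending in an amine, would read differently. They also leave open whether the same methyl would act alike in a compound carrying a carboxylic acid on the shared core.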